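This account rests on a few compounds, and the source may have more. Where it says the series, first, only, none or still open, it means among the compounds named here.

Compound 2, with the structure `C=C1CC[C@H]2C(C)(C)CCC[C@]2(C)[C@H]1C/C=C1/CC(O)OC1=O`, belongs to a small set of two terpenoid lactones examined for growth inhibition. In a functional assay on SK-N-SH cells (Homo sapiens) for inhibition, read by sulforhodamine B assay (a higher number here means a weaker inhibitor of growth, a lower number a stronger inhibitor of growth), compound 2 gives 20100 nM. Among the compounds with values here, the only other number comes from compound 1, whose structure is `CC1(C)CCC[C@]2(C)[C@@H](/C=C/C3=CC(=O)OC3)C(CO)=C(O)C(=O)[C@@H]12`; in this assay compound 1 gives 12100 nM, a value that lies within the usual scatter of the one for compound 2, so the two cannot be told apart on these data. Compound 3, with the structure `C=C1CC[C@H]2C(C)(C)CCC[C@]2(C)[C@H]1C/C=C1/CC(OC)OC1=O`, has not yet been tested in this assay. It differs from compound 2 in one place: methyl in place of hydrogen on an oxygen on a saturated carbon. Within the data shown here, with no other pair of measured compounds showing the same change, there is no basis for expecting a step beyond the scatter in either direction, and the step of a 1.1-fold lower number from compound 2 to compound 3 (0.05 log units; within the scatter) is estimated to be small. For compound 3 the expected value in this assay is 18000 nM, with a range from 7000 nM to 45000 nM.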

Compound 3, concentration for 50% growth inhibition: 13600 nM
Compound 3: middle estimate off by 1.3-fold (0.12 log units), on the high side, within the range that was stated.
By their numbers in this assay, from the lowest: compounds 1, 3 and 2 (each within the scatter of the next).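

Within the data shown here, replacing hydroxy with methoxy on this saturated carbon gives the first direct reading at this position: in this assay, the step is a 1.5-fold lower number from compound 2 to compound 3 (0.17 log units; within the scatter), which stays within the scatter. The hydrogen on this oxygen is therefore not required for growth inhibition at the level seen with compound 2, and on these data the hydroxy and methoxy forms cannot be told apart. Nothing available explains why the two forms read alike.

The compounds shown leave open whether a longer chain on this oxygen, such as ethoxy or benzyloxy, would give a step beyond the scatter. They also leave open what an amine or a carboxylic acid on this saturated carbon in place of the oxygen substituent would do.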